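Working notes on the aryl substituent of compound 2

The source may report more compounds than this note shows. Statements on the series, on what has been measured and on what is new or still open speak of the compounds shown alone.

Measured so far in a functional assay on BJAB cells (Homo sapiens) for antiproliferative activity, with a stated time of 4 days; a higher number here means that more compound is needed for the effect, a lower number that less compound is needed:
compound 1 `Cc1nn(-c2nc(-c3ccc(Cl)c(Cl)c3)c(SC(C)C)s2)c(C(=O)O)c1-c1ccccc1Cl` gives 13100 nM;
compound 2 `Cc1nn(-c2nc(-c3ccc(Cl)c(Cl)c3)c(SC(C)C)s2)c(C(=O)O)c1-c1cccc(Cl)c1` gives 13600 nM.

Compound 2 holds the higher of the two numbers, yet its nearest neighbour is compound 1 and the step of a 1.0-fold higher number from compound 1 to compound 2 (0.02 log units; within the scatter) lies within the scatter, so the two compounds are not distinguished in this assay.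

The next compound, compound 3 `CC(=O)Nc1ccc(-c2c(C)nn(-c3nc(-c4ccc(Cl)c(Cl)c4)c(SC(C)C)s3)c2C(=O)O)cc1`, differs from compound 2 by 4-acetamidophenyl in place of 3-chlorophenyl on an aromatic carbon. Among the compounds with values here, the only measured step, from compound 1 to compound 2, moved a chlorine around the same ring and gave no change beyond the scatter; it bears on the position that is varied, but nothing measured speaks to a group carrying a hydrogen-bond donor and acceptor at this place. No step beyond the scatter is therefore expected, with a wider uncertainty than that single step warrants. Compound 3 is estimated at 13000 nM, range 4000 nM to 45000 nM, which means an expected step of a 1.0-fold lower number from compound 2 to compound 3 (0.02 log units; within the scatter).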

Compound 3, half-maximal effective concentration: 139000 nM
For compound 3 the middle estimate is 11-fold (1.03 log units) below the measured one, outside the stated range (above it).
By their numbers in this assay, from the lowest: compounds 1 and 2 (each within the scatter of the next); then compound 3.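

In this assay the change to 4-acetamidophenyl gives a 10-fold higher number from compound 2 to compound 3 (1.01 log units; beyond the scatter) from 3-chlorophenyl and an 11-fold higher number from compound 1 to compound 3 (1.03 log units; beyond the scatter) from 2-chlorophenyl, so the number does depend on the aryl group at this place. Moving the chlorine around the ring had given no change beyond the scatter, and that tolerance does not extend to a phenyl ring carrying an acetamido group, with its hydrogen-bond donor and acceptor. No available data bear on the reason for this step.

The compounds shown do not separate the effect of removing the chlorine from that of adding the acetamido group, nor the acetamido group itself from its place on the phenyl ring. Unsubstituted phenyl, 4-chlorophenyl, 4-aminophenyl and 3-acetamidophenyl groups at this place would address these questions.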